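From 2-carboxyethyl to 2-carboxycyclohexyl on the shared core

The source may report more compounds than this note shows. Statements on the series, on what has been measured and on what is new or still open speak of the compounds shown alone.

In a functional assay on NCI-H441 cells (Homo sapiens) for antiproliferative activity, with a stated time of 24 h (on this read-out lower numbers stand for stronger inhibition and higher numbers for weaker inhibition), compound 1 `O=C1C(Cc2ccccc2F)CNCC1Cc1ccccc1F` gives 130000 nM and compound 2 `O=C(O)CCC(=O)N1C/C(=C\c2ccccc2F)C(=O)/C(=C/c2ccccc2F)C1` gives 69000 nM so the two numbers lie within the usual scatter of each other. Going by the values given here, compound 2 thus stands level with compound 1 on the only two numbers available. Compound 3 `O=C1/C(=C/c2ccccc2F)CN(C(=O)C2CCCCC2C(=O)O)C/C1=C\c1ccccc1F` keeps the shared core of compound 2 and carries 2-carboxycyclohexyl in place of 2-carboxyethyl on a carbonyl carbon is the whole difference. Among the compounds with values here, no measured pair differs in one place, so the data give no direct guide to the size of this change. In this assay no step beyond the scatter is expected, and no direction is favoured. The estimated step of a 1.3-fold lower number from compound 2 to compound 3 (0.10 log units; within the scatter) is expected to be small. For compound 3 the expected value is 55000 nM (estimated range 15000 nM to 150000 nM) with the wide range reflecting the lack of any measured step.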

Compound 3, half-maximal inhibitory concentration: 55000 nM
The estimate for compound 3 equals the measured number at the digits printed; low and high end bracket the measured number.
By their numbers in this assay, from the lowest: compounds 3, 2 and 1 (each within the scatter of the next, the first and the last beyond it).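

Going by these compounds alone, replacing 2-carboxyethyl with 2-carboxycyclohexyl on a carbonyl carbon gives the first single-place step: in this assay, it reads a 1.3-fold lower number from compound 2 to compound 3 (0.10 log units; within the scatter). This position therefore tolerates the group with the six-membered ring while keeping a carboxylic acid, with no step beyond the scatter on this read-out. Nothing available explains why the number holds at this level.

From the compounds shown here alone, whether the carboxylic acid matters at this position remains open, as a plain cyclohexyl group or a methyl ester on the same carbonyl carbon would separate the acid from the ring. Also open, going by these compounds, is whether a group of another kind, such as a primary amine or a longer chain ending in a carboxylic acid, would give a step beyond the scatter on the shared core.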